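The compounds below may be only part of what the source reports. "The series", "measured", "known", "first", "only" and "open" are said of these compounds alone.

In an ADME assay on microsomes from liver (Rattus norvegicus) for metabolic stability (a lower number here means that the compound disappears faster, a higher number that the compound lasts longer), compound 1 `Nc1nc(NCCNc2ncc(-c3ncc[nH]3)c(-c3cc(F)ccc3F)n2)ccc1[N+](=O)[O-]` gives > 0.5 h, which is a limit and not a number. Compound 2 `Nc1nc(NCCNc2ncc(-c3ncc[nH]3)c(-c3ccc(Cl)cc3F)n2)ccc1[N+](=O)[O-]` gives > 0.5 h, also a limit. Compound 3 `Nc1nc(NCCNc2ncc(-c3ncc[nH]3)c(-c3ccc(Br)cc3F)n2)ccc1[N+](=O)[O-]` gives > 0.5 h, again a limit. Compound 3 therefore stands with the other two at the limit of > 0.5 h in this assay, at which 3 of the 3 values shown sit.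

Compound 4 `COc1cc(Cl)ccc1-c1nc(NCCNc2ccc([N+](=O)[O-])c(N)n2)ncc1-c1ncc[nH]1` differs from compound 3 in one group: 4-chloro-2-methoxyphenyl in place of 4-bromo-2-fluorophenyl on an aromatic carbon. Put simply, 4-chloro-2-methoxyphenyl sits in place of 4-bromo-2-fluorophenyl on an aromatic carbon, ortho to a 1H-imidazol-2-yl group.

The measured steps offer little guidance. Bromo in place of chloro gave a step that the two limits leave unreadable from compound 2 to compound 3. Exchanging 2,5-difluorophenyl for 4-bromo-2-fluorophenyl gave a step that the two limits leave unreadable from compound 1 to compound 3, and exchanging it for 4-chloro-2-fluorophenyl gave a step that the two limits leave unreadable from compound 1 to compound 2. Within the data shown here, none of these has a readable size, and no measured compound carries a methoxy group. The series therefore points in no direction, and the expected change in this assay is a step that the limit leaves unreadable from compound 3 to compound 4, an estimate with no step beyond the usual scatter. The estimated half-life of compound 4 is 0.7 h, with an expected range from 0.3 h to 1.6 h.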

Compound 4, half-life: > 0.5 h
Compound 4: a limit, no number; the forecaster's own chance of this, stated with the estimate: 70%; the middle value does not contradict the limit.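

In this assay compound 4 gives > 0.5 h, which is a limit and not a number. Among these compounds, no step to compound 4 from compound 1, compound 2 or compound 3 can be read. The compounds shown leave open how long each one actually lasts, and whether any of these group exchanges changes that half-life at all.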